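Piperidinyl ester series: tert-butyl in place of cyano

This account rests on a few compounds, and the source may have more. Where it says the series, first, only, none or still open, it means among the compounds named here.

Three esters of the shared core have numbers in a functional assay on the whole organism with Mus musculus as the target (a lower number here means a less potent compound, a higher number a more potent compound, by a factor of ten per unit of this negative logarithm), so far. Compound 1 `CN1CCC(OC(=O)c2ccc(C#N)cc2)CC1` gives 1.65 in this assay, the highest of the three numbers. Compound 2 `CN1CCC(OC(=O)c2ccccc2F)CC1` gives 1.41 in this assay, and compound 3 `Cc1ccc(C)c(C(=O)OC2CCN(C)CC2)c1` gives 1.36 in this assay; both of these lie within the scatter of the number for compound 1, so no order among the three can be read from them. No pair of these compounds differs in a single place, and no step between measured compounds is available to guide the next one.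

Compound 4 `CN1CCC(OC(=O)c2ccc(C(C)(C)C)cc2)CC1` is the next member and awaits its number in this assay. It differs from compound 1 as follows: tert-butyl in place of cyano on an aromatic carbon. With no measured step of this kind in the series, and the three known numbers lying close together, the change is expected to move the number by little, if at all, beyond the scatter, in either direction. The step from compound 1 to compound 4 is estimated at a number 0.05 log units lower from compound 1 to compound 4 (within the scatter). Compound 4 is accordingly expected to give about 1.6 in this assay, with a range from 1.1 to 2.1.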

Compound 4, logarithm of the reciprocal of the active concentration, log(1/C): 1.13
Compound 4: the middle estimate sits 0.47 log units above what was measured, within the range that was stated.
By their numbers in this assay, from the lowest: compounds 4, 3, 2 and 1 (each within the scatter of the next, the first and the last beyond it).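

Working note on the aromatic carbon para to a large group: in this assay, tert-butyl in place of cyano gives a number 0.52 log units lower from compound 1 to compound 4 (beyond the scatter) and is the first single-place step in the series, so this position is not indifferent to the group it carries. Among these compounds, the change replaces a cyano group of 2 heavy atoms and 1 hydrogen-bond acceptor with a tert-butyl group of 4 heavy atoms and no hydrogen-bond acceptor, and it is the only comparison so far between compounds that differ in one place. No measurement bears on the origin of this step, so the data give no explanation for it.

The compounds shown leave open how a methoxy group or an amine at this same place would stand against cyano and tert-butyl, and whether the step follows the heavy-atom count or the hydrogen-bond acceptor. With a single step at this position, no trend across groups can be stated, and compounds 2 and 3 differ from compound 1 in more than one place, so they add no comparison here.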